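The source may report more compounds than this note shows. Statements on the series, on what has been measured and on what is new or still open speak of the compounds shown alone.

Among the compounds with values here, in a functional assay on the whole organism for antagonist activity, with Mus musculus as the target (a lower number here means that less compound is needed, a higher number that more compound is needed for the effect), three compounds with a shared core have numbers so far. Within the data shown here, compound 3 `CN(C)C1CCCC1N(C=O)c1ccc(Cl)c(Cl)c1` gives 40 mg/kg, its only single number, as two further records for it provide none. Compound 2 `CCC(=O)N(c1ccc(C)cc1)C1CCCC1N(C)C` gives 10 mg/kg; 10 mg/kg (2 entries), so more of compound 3 than of compound 2 is needed for the effect. Compound 1 `CCC(=O)N(c1ccc(OC)cc1)C1CCCC1N(C)C` gives 20 mg/kg; 20 mg/kg (2 entries), which lies within the usual scatter of both other values.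

Compound 4 `CCCC(=O)N(c1ccc(Cl)c(Cl)c1)C1CCCC1N(C)C` has not yet been measured. It differs from compound 3 by one change, propyl in place of hydrogen on a carbonyl carbon. Among the measured compounds shown here, no measured pair isolates this change, so any expectation is indirect. Compound 2 at 10 mg/kg; 10 mg/kg (2 entries) and compound 1 at 20 mg/kg; 20 mg/kg (2 entries) both carry a carbon chain rather than hydrogen on that carbonyl carbon, but they also differ from compound 3 elsewhere, and so little can be drawn from them. A modest move towards a lower dose is therefore expected, of a size not clearly beyond the scatter. The estimated step is a 2.0-fold lower number from compound 3 to compound 4 (0.30 log units; within the scatter). In this assay the expected value for compound 4 is 20 mg/kg, with an estimated range from 6 mg/kg to 60 mg/kg.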

Compound 4, dose for half-maximal effect: 7 mg/kg
Beside the measured number, compound 4's estimate is 2.9-fold (0.46 log units) above it; low and high end bracket the measured number.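

In this assay, within the data shown here, the exchange of hydrogen for propyl on a carbonyl carbon whose other neighbour is the amide-type nitrogen gives a 5.7-fold lower number from compound 3 to compound 4 (0.76 log units; beyond the scatter) and is the first change here isolated with the rest of the structure held fixed. Among these compounds, compounds 1 and 2 also carry a carbon chain at this carbonyl, but each differs from compound 3 in more than one place, so only this pair shows that the position responds to the change by more than the usual scatter. Nothing given here accounts for the size of this step, which rests on a single pair.

Going by these compounds, it remains open whether the trend continues with a longer chain such as butyl or hexyl, or whether a ring such as cyclopropyl or phenyl, or a carboxylic acid at the end of the chain, would behave like propyl at this carbonyl carbon. Among the compounds shown here, it is equally open whether the same exchange would give a step of similar size with the other aromatic substituents seen in compound 1 and compound 2, since no matching pair carries those groups.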